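Indole replacement at the aryl position of a pyrazolopyrimidine series

The compounds below may be only part of what the source reports. "The series", "measured", "known", "first", "only" and "open" are said of these compounds alone.

Measured so far in a functional assay on B16-F0 cells (Mus musculus) for inhibition, read by CCK-8 assay, with a stated time of 48 h; a higher number here means a weaker inhibitor, a lower number a stronger inhibitor:
- compound 1 `COc1cc(-c2ccnc3cc(-c4ccc5cc[nH]c5c4)nn23)cc(OC)c1OC` gives 55 nM
- compound 2 `COc1ccc(-c2cc3nccc(-c4cc(OC)c(OC)c(OC)c4)n3n2)cc1F` gives 3950 nM
- compound 3 `COc1cc(-c2ccnc3cc(-c4ccccc4)nn23)cc(OC)c1OC` gives 4730 nM

Compound 3 gives the highest number of the three. Its nearest neighbour is compound 2, and the step of a 1.2-fold higher number from compound 2 to compound 3 (0.08 log units; within the scatter) lies within the scatter, so the two cannot be ordered. The step of an 86-fold higher number from compound 1 to compound 3 (1.93 log units; beyond the scatter) is large, as is a 72-fold higher number from compound 1 to compound 2 (1.86 log units; beyond the scatter): of the three aryl groups tried on the shared core, only 1H-indol-6-yl has yielded a low number.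

Compound 4 `COc1cc(-c2ccnc3cc(-c4ccc5c(ccn5C)c4)nn23)cc(OC)c1OC` differs from compound 3 by 1-methyl-1H-indol-5-yl in place of phenyl on an aromatic carbon. The bearing steps are the two that lead away from compound 1. Both show that going from a bicyclic indole to a single six-membered ring raises the number by a large step; compound 4 reverses that direction. The new group is a 1-methyl-1H-indol-5-yl, with no hydrogen-bond donor and a different attachment point from the 1H-indol-6-yl of compound 1, so the full size of the step cannot be assumed. A large fall in this assay from compound 3 is expected, as a 14-fold lower number from compound 3 to compound 4 (1.13 log units; beyond the scatter), though smaller than the reverse of an 86-fold higher number from compound 1 to compound 3 (1.93 log units; beyond the scatter). Compound 4 is therefore estimated at 350 nM, in the range 50 nM to 2500 nM.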

Compound 4, half-maximal inhibitory concentration: 48 nM
For compound 4 the middle estimate is 7.3-fold (0.86 log units) above the measured one, and the stated range ends above it.
By their numbers in this assay, from the lowest: compounds 4 and 1 (each within the scatter of the next); then compounds 2 and 3 (each within the scatter of the next).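

In this assay the low number at this position is not confined to 1H-indol-6-yl: a 99-fold lower number from compound 3 to compound 4 (1.99 log units; beyond the scatter) and an 82-fold lower number from compound 2 to compound 4 (1.92 log units; beyond the scatter) are both large, so both indole-bearing compounds now stand well apart from the two carrying a single six-membered ring. With a 1.1-fold lower number from compound 1 to compound 4 (0.06 log units; within the scatter) lying within the scatter, compound 1 and compound 4 cannot be ordered, which shows that an indole with a methyl on its nitrogen, attached through a different ring carbon and with 0 hydrogen-bond donors in the entering group, is tolerated here. No measurement is available that explains these steps.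

The methyl and the change of attachment point arrive together, so 1H-indol-5-yl and 1-methyl-1H-indol-6-yl would be needed to separate them. Also open, from the compounds shown here alone, is whether the second ring must be an indole at all, as a benzimidazole, a quinoline or a phenyl carrying an amine at this position would test, and whether the result holds once the other aryl group, unchanged across all four compounds, is altered.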